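The source may hold more compounds than are shown below. What is called first, only, known or untested is meant among the compounds shown, and "the series" means these compounds.

Among the compounds with values here, in a functional assay on HEK293 cells with D(4) dopamine receptor (Homo sapiens) as the target, read by FLIPR (a higher number here means that more compound is needed for the effect, a lower number that less compound is needed), compound 2 `CCO/N=C(\CCN1CCN(c2ncccc2C#N)CC1)c1ccccc1` gives 139 nM and sits at one end of the two numbers so far, within the scatter of compound 1 `CCO/N=C(\CCN1CCN(c2ccccc2)CC1)c1ccccc1`, which gives 109 nM; the step between them is a 1.3-fold higher number from compound 1 to compound 2 (0.11 log units; within the scatter). Compound 3 `CCO/N=C(\CCN1CCN(c2ncccc2C)CC1)c1ccccc1` differs from compound 2 by methyl in place of cyano on an aromatic carbon. Within the data shown here, the one step on record exchanges the whole aryl group on the ring nitrogen and stayed within the scatter; no measured step exchanges cyano for methyl. The step from compound 2 to compound 3 is therefore expected to be a 1.1-fold lower number from compound 2 to compound 3 (0.03 log units; within the scatter), nothing beyond the scatter. For compound 3 the estimate in this assay is 130 nM, expected between 60 nM and 300 nM.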

Compound 3, half-maximal effective concentration: 253 nM
Compound 3: the middle estimate sits 1.9-fold (0.29 log units) below what was measured; the range from low to high includes it.
By their numbers in this assay, from the lowest: compounds 1, 2 and 3 (each within the scatter of the next, the first and the last beyond it).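

In this assay, methyl in place of cyano on this aromatic carbon, ortho to a large group, gives a 1.8-fold higher number from compound 2 to compound 3 (0.26 log units; within the scatter) and so stays within the scatter. Against the phenyl of compound 1, the 3-methylpyridin-2-yl group gives the first step of the series beyond the scatter, though a modest one, a 2.3-fold higher number from compound 1 to compound 3 (0.37 log units; beyond the scatter), while the 3-cyanopyridin-2-yl group gave only a 1.3-fold higher number from compound 1 to compound 2 (0.11 log units; within the scatter). Nothing on hand explains either step. Open, going by these compounds, is how a methoxy group, a chlorine or an amine on this same carbon would read in this assay.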